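Methoxy addition on two chalcone-type cores, antiproliferative series

The compounds below may be only part of what the source reports. "The series", "measured", "known", "first", "only" and "open" are said of these compounds alone.

Compound 1 `C=C(Br)C(=O)Nc1ccc(/C=C/C(=O)c2ccccc2)cc1` gives 5000 nM in a functional assay on L1210 cells (Mus musculus) for antiproliferative activity, with a stated time of 48 h; a higher number here means a weaker inhibitor, a lower number a stronger inhibitor. Compound 2 `C=C(Br)C(=O)Nc1ccc(/C=C/C(=O)c2ccc(OC)cc2)cc1` carries the change methoxy in place of hydrogen on an aromatic carbon and in this assay compound 2 gives 980 nM; the step is a 5.1-fold lower number from compound 1 to compound 2 (0.71 log units; beyond the scatter). Compound 3 `COc1cc(/C=C/C(=O)c2ccc(N)cc2)cc(OC)c1` belongs to a different core; how the core of compound 3 differs from the core of compound 1 is not broken down here. In this assay compound 3 gives 6000 nM, which lies within the scatter of compound 1, while its gap to compound 2 is beyond the scatter. Compound 4 `COc1cc(/C=C/C(=O)c2ccc(N)cc2)cc(OC)c1OC` is not yet measured; it differs from compound 3 by methoxy in place of hydrogen on an aromatic carbon. This is the same kind of change as that from compound 1 to compound 2, but the place is not identical: in compound 4 the entering methoxy sits ortho to two methoxy groups as well as para to a large group, whereas in compound 2 it sits only para to a large group. Because a 5.1-fold lower number from compound 1 to compound 2 (0.71 log units; beyond the scatter) was a modest step from a single instance and the surroundings of the place differ, compound 4 is expected to show a step of a 2.4-fold lower number from compound 3 to compound 4 (0.38 log units; beyond the scatter). In this assay compound 4 is estimated at 2500 nM, between 700 nM and 8000 nM.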

Compound 4, half-maximal inhibitory concentration: 7800 nM
Compound 4: middle estimate off by 3.1-fold (0.49 log units), on the low side; the range from low to high includes it.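

In this assay, methoxy in place of hydrogen on an aromatic carbon gives a 1.3-fold higher number from compound 3 to compound 4 (0.11 log units; within the scatter), so on the core of compound 3 this change shows no effect that stands clear of the scatter. Set beside the earlier step, the size of the change does not carry over from the core of compound 1 to the core of compound 3: the same change on two cores in this assay, a 5.1-fold lower number (0.71 log units; beyond the scatter) from compound 1 to compound 2 and a 1.3-fold higher number (0.11 log units; within the scatter) from compound 3 to compound 4, 6.6-fold (0.82 log units) apart, beyond the scatter of two such steps. What separates the two steps is not shown: the cores differ, the entering methoxy in compound 4 is also ortho to two methoxy groups, and two pairs set no rule for other cores in the series.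

From the compounds shown here alone, it remains open whether the core or the surroundings of the place decide the size of the step, and a methoxy entering the core of compound 3 without two methoxy groups ortho to it would help separate the two. Also open, going by these compounds, is how a hydroxyl or an ethoxy would behave at the same place on that core.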